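Replacing the hydroxyphenyl on the triazole with a silicon group

The source may report more compounds than this note shows. Statements on the series, on what has been measured and on what is new or still open speak of the compounds shown alone.

The series rests on a shared core carrying a triazole with a large group on one of its aromatic carbons. For the measured compounds named here, compound 1, `O=C1O[C@H]([C@@H](O)Cn2cc(-c3cccc(O)c3)nn2)C(OCc2ccccc2)=C1OCc1ccccc1`, was measured in a functional assay on HCT-116 cells (Homo sapiens) for antiproliferative activity, read by MTT assay, with a stated time of 72 h (on this read-out lower numbers stand for stronger inhibition and higher numbers for weaker inhibition), and gives 42900 nM, the lowest of the two numbers so far. Compound 2, `O=C1O/C(=C\Cn2cc(-c3cccc(O)c3)nn2)C(OCc2ccccc2)=C1OCc1ccccc1`, differs in the linker between the core and the triazole; in this assay compound 2 gives 63600 nM, which lies within the scatter of the value of compound 1, so the two show no ordering.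

Compound 3, `C[Si](C)(C)c1cn(C[C@H](O)[C@H]2OC(=O)C(OCc3ccccc3)=C2OCc2ccccc2)nn1`, has not yet been measured. It differs from compound 1 in one place: a group of 4 heavy atoms (3 carbon, 1 silicon; no ring) in place of a group of 7 heavy atoms (6 carbon, 1 oxygen; one six-membered aromatic ring of carbon only), on an aromatic carbon. Going by the values given here, no step between two measured compounds resembles this change, so the expectation rests on the weak activity already seen. Because compound 1 gives only 42900 nM, compound 3 is expected to stay in the same weak range, with a step of a 1.5-fold higher number from compound 1 to compound 3 (0.18 log units; within the scatter) that is small or none beyond the scatter, toward a somewhat higher number if anything. Compound 3 is therefore estimated at 65000 nM, within a range from 25000 nM to 170000 nM.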

Compound 3, half-maximal inhibitory concentration: 31800 nM
The estimate for compound 3 lay 2.0-fold (0.31 log units) above the measured number, and the stated range covers the measured number.
By their numbers in this assay, from the lowest: compounds 3, 1 and 2 (each within the scatter of the next).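

This is the first change shown at the aromatic carbon of the triazole, since compound 2 differed from compound 1 only in the linker. In this assay, replacing the 3-hydroxyphenyl with the silicon group, which has no ring and no hydrogen-bond donor or acceptor, gives a 1.3-fold lower number from compound 1 to compound 3 (0.13 log units; within the scatter), so the two compounds show no ordering. At this position and in this pair, then, neither the six-membered aromatic ring nor the hydroxyl group of compound 1 is needed to keep the number where it stands, and no measurement shown explains why the exchange leaves it there.

With only this one exchange at the position, the compounds shown leave open whether a tert-butyl group, which would put carbon where compound 3 has silicon, would give a similar number, and whether an amine, a carboxylic acid or a longer chain on the same carbon would move the number beyond the scatter. They also leave open whether the silicon group would behave the same way on the linker of compound 2.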